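Methyl for 2-phenylethenyl on a carbonyl carbon

The compounds below may be only part of what the source reports. "The series", "measured", "known", "first", "only" and "open" are said of these compounds alone.

In a functional assay on HepG2 cells (Homo sapiens) for inhibition, read by MTT assay, with a stated time of 48 h (a lower number here means a stronger inhibitor, a higher number a weaker inhibitor), compound 1 (`CC(=O)c1ccc(Nc2c(C(C)=O)sc(NC(=O)CC#N)c2C#N)cc1`) gives 56100 nM and compound 2 (`CC(=O)Nc1sc(C(C)=O)c(Nc2ccc(C(C)=O)cc2)c1C#N`) gives 66200 nM, while compound 3 (`CC(=O)c1ccc(Nc2c(C(=O)/C=C/c3ccccc3)sc(N)c2C#N)cc1`) gives 73600 nM within the scatter of both. Compound 4 (`CC(=O)c1ccc(Nc2c(C(C)=O)sc(N)c2C#N)cc1`) differs from compound 3 (methyl in place of 2-phenylethenyl on a carbonyl carbon): methyl in place of 2-phenylethenyl on a carbonyl carbon. Within the data shown here, the only measured step (a 1.2-fold higher number from compound 1 to compound 2 (0.07 log units; within the scatter)) falls at another place and stays within the scatter, so it does not test this change directly. Compound 2 already carries methyl on that carbonyl carbon and gives 66200 nM within the scatter of compound 3. In this assay the expected move is a 1.1-fold lower number from compound 3 to compound 4 (0.05 log units; within the scatter) and no larger than the scatter. For compound 4 the estimate is 65000 nM (expected range 30000 nM to 140000 nM).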

Compound 4, half-maximal inhibitory concentration: 88500 nM
For compound 4 the middle estimate is 1.4-fold (0.13 log units) below the measured one, within the range that was stated.
By their numbers in this assay, from the lowest: compounds 1, 2, 3 and 4 (each within the scatter of the next).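

In this assay, replacing 2-phenylethenyl with methyl on a carbonyl carbon gives a 1.2-fold higher number from compound 3 to compound 4 (0.08 log units; within the scatter), so this position tolerates losing the aromatic ring and the double bond without a change beyond the scatter. The same holds on the nitrogen on an aromatic ring: hydrogen in place of acetyl gives a 1.3-fold higher number from compound 2 to compound 4 (0.13 log units; within the scatter), and hydrogen in place of (cyanomethyl)carbonyl gives a 1.6-fold higher number from compound 1 to compound 4 (0.20 log units; within the scatter). No measured evidence explains this flat response. Still open, on these data alone, is whether a carboxylic acid or a longer alkyl chain on that carbonyl carbon would move the number beyond the scatter.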